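This account rests on a few compounds, and the source may have more. Where it says the series, first, only, none or still open, it means among the compounds named here.

Measured so far in an ADME assay on HEK293 cells (Homo sapiens) for cytotoxicity, read by resazurin assay, with a stated time of 48 h; on this read-out lower numbers stand for higher toxicity in this test and higher numbers for lower toxicity in this test:
- compound 1 `O=S(=O)(Nc1ccc2oc(-c3ccccc3)nc2c1)c1cccc(O)c1`: > 100000 nM
- compound 2 `COc1ccc(S(=O)(=O)Nc2ccc3oc(-c4ccccc4)nc3c2)cc1`: 91000 nM

The entry for compound 1 of > 100000 nM is a limit of the assay and not a number. For the measured compounds named here, compound 2, at 91000 nM, therefore holds the only true number in this assay.

Compound 3 `O=S(=O)(Nc1ccc2oc(-c3ccccc3)nc2c1)c1ccc(O)cc1` differs from compound 2 by hydrogen in place of methyl on an oxygen on an aromatic ring, so that 4-methoxyphenyl becomes 4-hydroxyphenyl.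

Going by the values given here, only one measured step bears on this change, and only indirectly. That step, an at least 1.0-fold lower number from compound 1 to compound 2 (0.04 log units; that floor lies within the scatter), put 4-methoxyphenyl in place of 3-hydroxyphenyl on a sulfonyl sulfur. It gives only a floor, and that floor lies within the scatter. Nothing measured therefore points to a real shift, and no step beyond the scatter is expected in this assay.

The expected step is a 1.1-fold higher number from compound 2 to compound 3 (0.04 log units; within the scatter), which stays within the scatter. The assay may well report only a limit for this compound.

For compound 3 the estimate is 100000 nM, with an expected range from 45000 nM to 200000 nM.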

Compound 3, half-maximal cytotoxic concentration: > 100000 nM
Compound 3: only a limit was reported; the forecaster's own chance of this, stated with the estimate: 55%; the middle value lies on the limit itself.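

In this assay compound 3 gives > 100000 nM, which is a limit of the assay and not a number. Hydrogen in place of methyl on an oxygen on an aromatic ring, the first change shown that leaves the position of the oxygen on the ring untouched, gives an at least 1.0-fold higher number from compound 2 to compound 3 (0.04 log units; that floor lies within the scatter), so turning 4-methoxyphenyl into 4-hydroxyphenyl shows no move towards a lower number, and thus none towards higher toxicity in this test. Neither the step between compound 1 and compound 3, which swaps 3-hydroxyphenyl for 4-hydroxyphenyl, nor the full size of the change from methoxy to hydroxy can be read, because these comparisons rest on a limit: the limit of > 100000 nM in this assay, at which 2 of the 3 values shown sit.

Going by these compounds, whether an amine or a carboxylic acid in place of the hydroxy group, or a longer chain in place of methyl on the oxygen, would bring a number clearly below that of compound 2 stays open. The compounds shown also leave open what true numbers compound 1 and compound 3 would give.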